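The compounds below may be only part of what the source reports. "The series", "measured", "known", "first", "only" and "open" are said of these compounds alone.

Measured so far in a functional assay on DU-145 cells (Homo sapiens) for antiproliferative activity, read by sulforhodamine B assay; on this read-out lower numbers stand for stronger inhibition and higher numbers for weaker inhibition:
compound 1 `CCCCCCCCCCCCCCCCCCNC(=O)[C@H]1CSC(c2ccc(F)cc2)N1`: 5700 nM
compound 2 `CCCCCCCCCCCCCCCCCCNC(=O)[C@H]1CSC(c2cc(F)cc(F)c2)N1`: > 20000 nM, a limit

Compound 2 stands at the limit of this assay, the one noted in the limit of > 20000 nM in this assay, at which 1 of the 2 values shown sits, so no number is known for it. Among the measured compounds shown here, the only measured step, an at least 3.5-fold higher number from compound 1 to compound 2 (0.54 log units; beyond the scatter), moves from 4-fluorophenyl to 3,5-difluorophenyl and ends at that limit. Compound 3 `CCCCCCCCCCCCCCCCCCNC(=O)[C@H]1CSC(c2ccc(C)cc2)N1` differs from compound 2 by 4-methylphenyl in place of 3,5-difluorophenyl on a saturated ring carbon, which returns to a phenyl bearing a single substituent, the arrangement already seen with the 4-fluorophenyl of compound 1. The measured step bears on the new one in reverse: leaving 3,5-difluorophenyl is expected to give a lower number, of roughly the size seen before, though the starting point is only a limit. The reference is compound 1 with its 5700 nM. The estimate for compound 3 is 7000 nM, range 2500 nM to 20000 nM, meaning an expected step of an at least 2.8-fold lower number from compound 2 to compound 3 (0.45 log units; beyond the scatter).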

Compound 3, half-maximal inhibitory concentration: 10500 nM
Beside the measured number, compound 3's estimate is 1.5-fold (0.18 log units) below it; the range from low to high includes it.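

In this assay there is a 1.8-fold higher number from compound 1 to compound 3 (0.27 log units; within the scatter), so 4-methylphenyl and 4-fluorophenyl on this saturated ring carbon are not told apart, and methyl in place of fluoro has no readable effect here. Leaving 3,5-difluorophenyl gives an at least 1.9-fold lower number from compound 2 to compound 3 (0.27 log units; that floor lies within the scatter), so this step alone does not establish a gain for compound 3 over compound 2. Compound 2 has only a limit, which leaves the true size of that step unknown: the limit of > 20000 nM in this assay, at which 1 of the 3 values shown sits.

Open, on these data alone, is whether a single substituent of another kind on this phenyl, such as a methoxy group, an amine or a carboxylic acid, would move the number beyond the scatter from compound 1. Also open, as far as these compounds go, is how a phenyl bearing two methyl groups would compare with the 3,5-difluorophenyl of compound 2.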